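Adding a Hydroxy Group: Does a Small Step Repeat?

The source may hold more compounds than are shown below. What is called first, only, known or untested is meant among the compounds shown, and "the series" means these compounds.

Compound 1 `O=C1CSC(c2ccccc2)N1n1c(CSc2nnc(-c3ccncc3)o2)nc2ccc(Br)cc2c1=O` and compound 2 `O=C1CSC(c2ccc(O)cc2)N1n1c(CSc2nnc(-c3ccncc3)o2)nc2ccc(Br)cc2c1=O` were both tested in a functional assay on the whole organism (strain Charles-Foster albino) for inhibition, with Rattus norvegicus as the target, read by paw edema, at a dose of 50 mg/kg by the oral route; a higher number here means more inhibition at the dose given (going by the name of the read-out), a lower number less inhibition. Compound 1 gives 31.3%, and compound 2 gives 32.7%. The change between them, (hydroxy in place of hydrogen on an aromatic carbon), made a number 1.4 percentage points higher from compound 1 to compound 2 (within the scatter). Compound 3 `O=c1c2ccccc2nc(CSc2nnc(-c3ccncc3)o2)n1/N=C/c1ccccc1` is built on a different core; the difference between the two cores is not broken down here. In this assay compound 3 gives 16.3%, the lowest of the three numbers, and its gap to the others lies beyond the scatter. Compound 4 `O=c1c2ccccc2nc(CSc2nnc(-c3ccncc3)o2)n1/N=C/c1ccc(O)cc1` has not yet been measured; it differs from compound 3 by hydroxy in place of hydrogen on an aromatic carbon, the same change, at the same place, that turned compound 1 into compound 2. Because the earlier step of a number 1.4 percentage points higher from compound 1 to compound 2 (within the scatter) stayed within the scatter, a similarly small step is expected, a number 1.7 percentage points higher from compound 3 to compound 4 (within the scatter). Compound 4 is therefore estimated at 18%, with a likely range from 8% to 28%.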

Compound 4, a percentage reported as inhibition, in the whole organism at one dose (the size of the read-out at that dose, not a potency): 18.2%
For compound 4 the middle estimate is 0.2 percentage points below the measured one, and the stated range covers the measured number.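

Swapping phenyl for 4-hydroxyphenyl gives a number 1.9 percentage points higher from compound 3 to compound 4 (within the scatter) in this assay, so the small step seen on the core of compound 1 is seen again on the core of compound 3. The two steps agree: the same change on two cores in this assay, a number 1.4 percentage points higher (within the scatter) from compound 1 to compound 2 and a number 1.9 percentage points higher (within the scatter) from compound 3 to compound 4, 0.5 percentage points apart, within the scatter of two such steps. This shows that, on these two cores, the swap carries over as a step too small to tell apart from the scatter; it does not show that the hydroxy group has any real effect on inhibition, or that a third core would behave alike.

The compounds shown leave open what other groups at this place would do, such as an amine, a carboxylic acid or a methoxy group.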